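Trading one nitro for bromo in a growth inhibitor

This account rests on a few compounds, and the source may have more. Where it says the series, first, only, none or still open, it means among the compounds named here.

Two related compounds have been measured so far in a functional assay on MCF7 cells (Homo sapiens) for inhibition, read by sulforhodamine B assay, with a stated time of 48 h; a higher number here means a weaker inhibitor of growth, a lower number a stronger inhibitor of growth. Compound 1 (`N#CCC1=NN=C(c2ccc(Br)cc2)C(CC(=O)c2ccc(Br)cc2)O1`), which carries two 4-bromophenyl groups, gives 30400 nM. Compound 2 (`N#CCC1=NN=C(c2ccc([N+](=O)[O-])cc2)C(CC(=O)c2ccc([N+](=O)[O-])cc2)O1`), which carries two 4-nitrophenyl groups, gives 1600 nM. That is the lower of the two numbers, which makes compound 2 the stronger inhibitor, by a gap beyond the usual scatter. Compound 3 (`N#CCC1=NN=C(c2ccc([N+](=O)[O-])cc2)C(CC(=O)c2ccc(Br)cc2)O1`) is compound 2 with bromo in place of nitro on an aromatic carbon, para to a large group: bromo in place of nitro on an aromatic carbon. It therefore keeps one 4-nitrophenyl group and gains one 4-bromophenyl group. With compound 1 at 30400 nM, this single swap is expected to raise the number, though only partway. The estimated step is a 4.4-fold higher number from compound 2 to compound 3 (0.64 log units; beyond the scatter), towards a weaker inhibitor and probably beyond the scatter. Compound 3 is estimated at 7000 nM, with a range from 2000 nM to 25000 nM.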

Compound 3, concentration for 50% growth inhibition: 36000 nM
Estimate against measurement, compound 3: 5.1-fold (0.71 log units) below; the whole stated range lies below it.
By their numbers in this assay, from the lowest: compound 2; then compounds 1 and 3 (each within the scatter of the next).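

In this assay, replacing only one nitro with bromo is enough to lose the advantage of compound 2: the step of a 23-fold higher number from compound 2 to compound 3 (1.35 log units; beyond the scatter) is large. Placing nitro in place of bromo on the other ring gives a 1.2-fold higher number from compound 1 to compound 3 (0.07 log units; within the scatter) and cannot be told apart from no change, so a single 4-nitrophenyl group on that ring does not restore the low number of compound 2. Among these compounds, the low number appears only with 4-nitrophenyl groups on both rings, and nothing measured here explains why. The compounds shown leave open whether the reverse arrangement, with nitro and bromo exchanged between the two rings, would behave like compound 3. They also leave open how an amine or a carboxylic acid would fare at this position.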